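Replacing 4-cyanophenyl when only limits are known

A few compounds are considered here, and "the series" means these few. Any claim that something is new, unique, unknown or untested is made for them only; others in the source may bear on it.

In an ADME assay on BJ cells (Homo sapiens) for cytotoxicity, with a stated time of 72 h (on this read-out lower numbers stand for an effect already at smaller amounts and higher numbers for an effect only at larger amounts of compound), two compounds sharing one core have been tested so far. Compound 1 `COc1ccc(-c2nc3c(c(C)nn3-c3ccccc3)c(-c3ccccc3O)c2C#N)cc1` gives > 23000 nM, which is a limit of the assay and not a number. Compound 2 `Cc1nn(-c2ccccc2)c2nc(-c3ccc(C#N)cc3)c(C#N)c(-c3ccccc3O)c12` gives > 20000 nM, which is also a limit. Among the compounds with values here, compound 2 therefore has no exact position on the scale, and neither does the only other compound measured. Within the data shown here, the one measured change, cyano in place of methoxy on an aromatic carbon, is a step that the two limits leave unreadable from compound 1 to compound 2, so it offers no size to carry forward.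

Compound 3 `Cc1nn(-c2ccccc2)c2nc(-c3ccc4c(c3)CCCC4)c(C#N)c(-c3ccccc3O)c12` differs from compound 2 at another place: 1,2,3,4-tetrahydronaphthalen-6-yl in place of 4-cyanophenyl on an aromatic carbon. In words, 1,2,3,4-tetrahydronaphthalen-6-yl stands in place of 4-cyanophenyl on an aromatic carbon. Among the measured compounds shown here, no measured step covers this exchange, so the expectation rests on compound 2 and its limit of > 20000 nM. The expected step of a number no higher from compound 2 to compound 3 (the limit leaves the size open) is no more than the usual scatter, with no direction favoured. Compound 3 is estimated at 20000 nM, with an expected range from 7000 nM to 40000 nM.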

Compound 3, half-maximal effective concentration: > 20000 nM
Compound 3 was reported as a limit; the forecaster's own chance of this, stated with the estimate: 70%; the middle value sits exactly at the limit.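

In this assay compound 3 gives > 20000 nM, which is a limit of the assay and not a number. Compound 1 and compound 2 also stand only at limits, so no step among these three compounds can be read. The compounds shown leave open at what concentration, if any, each one affects these cells.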